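This account rests on a few compounds, and the source may have more. Where it says the series, first, only, none or still open, it means among the compounds named here.

Of the compounds shown here, two built on the shared core have been measured so far. Compound 1 `O=C(CCCc1ccc(Cl)cc1)N1CCc2c(Cl)c(O)c(O)c(Cl)c2C1` gives 80% in a functional assay (Homo sapiens), tested at 1 uM (on this read-out lower numbers stand for a stronger effect and higher numbers for a weaker effect at the one concentration tested), the lower of the two numbers. Compound 2 `O=C(/C=C/c1ccccc1)N1CCc2c(Cl)c(O)c(O)c(Cl)c2C1` gives 83% in this assay, which lies within the scatter of the number for compound 1, so the two cannot be set apart. Compound 3 `O=C(CCCc1ccc(F)cn1)N1CCc2c(Cl)c(O)c(O)c(Cl)c2C1` is not yet measured and differs from compound 1 in one place: 5-fluoropyridin-2-yl in place of 4-chlorophenyl on a saturated chain carbon, three bonds along the chain from a carbonyl carbon. Going by the values given here, no measured pair shows such a change, so the expectation rests on compound 1 alone; a step of about a number 6 percentage points higher from compound 1 to compound 3 (within the scatter) is expected, hardly beyond the scatter. Compound 3 is accordingly estimated at 86%, with a range from 70% to 100%.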

Compound 3, a percentage reported as activity, at one concentration (the size of the read-out at that concentration, not a potency): 89%
Compound 3: the middle estimate sits 3 percentage points below what was measured; low and high end bracket the measured number.
By their numbers in this assay, from the lowest: compounds 1, 2 and 3 (each within the scatter of the next).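

Exchanging 4-chlorophenyl for 5-fluoropyridin-2-yl on a saturated chain carbon, three bonds along the chain from a carbonyl carbon, gives in this assay a step of a number 9 percentage points higher from compound 1 to compound 3 (within the scatter), so the two compounds cannot be set apart. At this position, therefore, a ring with one hetero atom and one hydrogen-bond acceptor reads the same as the carbon-only ring within the scatter. No available evidence bears on this result.

Open, going by these compounds, is whether any group at this position moves the read-out beyond the scatter. An amine, a carboxylic acid or a longer chain in place of the aromatic ring would test this.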